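Adding a methoxyphenyl group to a weak antiproliferative amide

The source may hold more compounds than are shown below. What is called first, only, known or untested is meant among the compounds shown, and "the series" means these compounds.

Of the compounds shown here, three have so far been tested in a functional assay on A-375 cells (Homo sapiens) for antiproliferative activity, read by MTT assay, with a stated time of 72 h; a lower number here means a stronger inhibitor, a higher number a weaker inhibitor. Compound 3 `O=C1COc2ccc(-c3cnc(Cl)c(NS(=O)(=O)c4ccc(F)cc4)c3)cc2N1` reports only a limit, > 40000 nM. Compound 1 `COc1cccc(N2C(=O)COc3ccc(-c4cnc(Cl)c(NS(=O)(=O)c5ccc(F)cc5)c4)cc32)c1` likewise reports only a limit, > 40000 nM. For the measured compounds named here, compound 2 `O=C1COc2ccc(-c3cccc(NS(=O)(=O)c4ccc(F)cc4)c3)cc2N1` gives the one number in this assay, 20100 nM. The difference between the core of compound 2 and that of compound 3 is not broken down here.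

From compound 3 to compound 1 the change is 3-methoxyphenyl in place of hydrogen on an amide-type nitrogen in a ring, and the step it made is a step that the two limits leave unreadable from compound 3 to compound 1, because both compounds sit at the limit of > 40000 nM in this assay, at which 2 of the 3 values shown sit.

Compound 4 `COc1cccc(N2C(=O)COc3ccc(-c4cccc(NS(=O)(=O)c5ccc(F)cc5)c4)cc32)c1` is not yet measured. From compound 2 it carries the same change, (3-methoxyphenyl in place of hydrogen on an amide-type nitrogen in a ring). Going by the values given here, the study therefore gives no readable step for this change, and the only anchor is compound 2 with its value of 20100 nM.

The author estimates that the step from compound 2 to compound 4 in this assay will be a 1.5-fold higher number from compound 2 to compound 4 (0.17 log units; within the scatter), and expects compound 4 to fall near 30000 nM, somewhere between 8000 nM and 100000 nM, with a real chance that this assay reports only a limit.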

Compound 4, half-maximal inhibitory concentration: > 40000 nM
Compound 4 was reported as a limit; the forecaster's own chance of this, stated with the estimate: 45%; middle value at least 1.3-fold (0.12 log units) away from the limit.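

Compound 4 reports only a limit in this assay, > 40000 nM. Placing 3-methoxyphenyl on the amide-type nitrogen gives an at least 1.9-fold higher number from compound 2 to compound 4 (0.29 log units; that floor lies within the scatter), so only a floor can be read, and it does not establish a real loss of activity on this core or give the true size of the step. The same change cannot be read on the core of compound 3 either, so the two cores neither agree nor disagree on its size, and whether it carries from one core to the other stays unsettled because compound 1, compound 3 and compound 4 all end at the same limit: the limit of > 40000 nM in this assay, at which 3 of the 4 values shown sit.

The compounds shown leave open whether another group on this nitrogen, such as methyl or a longer chain ending in an amine or a carboxylic acid, would give a number rather than a limit. They also leave open how the two cores would compare on a pair in which both members give a number.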